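Working notes: compound 2 to compound 4 in cell toxicity

The compounds below may be only part of what the source reports. "The series", "measured", "known", "first", "only" and "open" are said of these compounds alone.

Measured in a functional assay on CCRF-CEM cells (Homo sapiens) for cytotoxicity, read by MTT assay, with a stated time of 72 h; on this read-out lower numbers stand for higher toxicity in this test and higher numbers for lower toxicity in this test:
- compound 1 `O=C(Nc1ccc([Se][Se]c2ccc(NC(=O)OCc3ccccc3)cc2)cc1)OCc1ccccc1`: 67900 nM
- compound 2 `CCCCOC(=O)Nc1ccc([Se]C#N)cc1`: 63500 nM
- compound 3 `CCCCCCOC(=O)Nc1ccc([Se][Se]c2ccc(NC(=O)OCCCCCC)cc2)cc1`: 67300 nM

In this assay compound 2 stands at the lowest of the three numbers, yet compound 3 and compound 1 both lie within the scatter of it, so no order among the three is claimed. Compound 4 `C=CCOC(=O)Nc1ccc([Se]C#N)cc1` differs from compound 2 by vinyl in place of propyl on a saturated chain carbon bound to an oxygen next to a carbonyl group. Within the data shown here, no step between two measured compounds is available to size this change against. The change is small in what it counts, so the expected step from compound 2 to compound 4 in this assay is a 1.1-fold lower number from compound 2 to compound 4 (0.02 log units; within the scatter), taken as none beyond the scatter. Compound 4 is therefore estimated at 60000 nM in this assay, with a range from 30000 nM to 120000 nM.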

Compound 4, concentration lethal to 50% of the cells: 68600 nM
For compound 4 the middle estimate is 1.1-fold (0.06 log units) below the measured one; low and high end bracket the measured number.
By their numbers in this assay, from the lowest: compounds 2, 3, 1 and 4 (each within the scatter of the next).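

In this assay, among these compounds, vinyl in place of propyl on a saturated chain carbon bound to an oxygen next to a carbonyl group gives a 1.1-fold higher number from compound 2 to compound 4 (0.03 log units; within the scatter), the first step that can be read at this position. Butoxy and allyloxy are thus not told apart in this test, and the double bond outside aromatic rings brings no shift beyond the scatter. No supporting data bear on this result. Going by these compounds, whether a longer chain, or an amine or carboxylic acid at the end of the chain, would move the number beyond the scatter at this position stays open.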